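Moving the halogen around the triazole-linked phenyl ring

This account rests on a few compounds, and the source may have more. Where it says the series, first, only, none or still open, it means among the compounds named here.

Within the data shown here, compound 1 `O=c1[nH]cc(S(=O)(=O)Nc2ccccc2-c2cn(-c3ccccc3F)nn2)c(=O)[nH]1` is the only compound here with a measured number: in a functional assay on HepG2 cells (Homo sapiens) for antiproliferative activity, read by MTT assay, with a stated time of 24 h (on this read-out lower numbers stand for stronger inhibition and higher numbers for weaker inhibition), compound 1 gives 12500 nM. Compound 2 `O=c1[nH]cc(S(=O)(=O)Nc2ccccc2-c2cn(-c3cccc(F)c3)nn2)c(=O)[nH]1` carries 3-fluorophenyl in place of 2-fluorophenyl on an aromatic nitrogen. In this assay compound 2 gives only a limit of the assay, > 20000 nM. That step, an at least 1.6-fold higher number from compound 1 to compound 2 (0.20 log units; that floor lies within the scatter), points toward weaker inhibition, though its floor sits inside the scatter (the limit of > 20000 nM in this assay, at which 1 of the 2 values shown sits). Compound 3 `O=c1[nH]cc(S(=O)(=O)Nc2ccccc2-c2cn(-c3ccc(Cl)cc3)nn2)c(=O)[nH]1` differs from compound 1 by 4-chlorophenyl in place of 2-fluorophenyl on an aromatic nitrogen. Among the measured compounds shown here, only the step to compound 2 bears on this change, so a small weakening is expected; for compound 3 the expected step is a 1.4-fold higher number from compound 1 to compound 3 (0.16 log units; within the scatter). The estimate for compound 3 is 18000 nM, between 8000 nM and 40000 nM.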

Compound 3, half-maximal inhibitory concentration: 1840 nM
The estimate for compound 3 lay 9.8-fold (0.99 log units) above the measured number; measured number below the stated range.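

In this assay, the group on this aromatic nitrogen clearly matters: 4-chlorophenyl in place of 2-fluorophenyl gives a 6.8-fold lower number from compound 1 to compound 3 (0.83 log units; beyond the scatter). Against 3-fluorophenyl, it gives an at least 10-fold lower number from compound 2 to compound 3 (1.03 log units; beyond the scatter). That second step is only a floor, since compound 2 stands at a limit of the assay: the limit of > 20000 nM in this assay, at which 1 of the 3 values shown sits.

Both the halogen and its place on the phenyl ring change in these steps, so the compounds shown cannot separate the two. They also leave open how a phenyl ring carrying an amine or a carboxylic acid instead of a halogen would behave.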